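The compounds below may be only part of what the source reports. "The series", "measured", "known", "first", "only" and "open" are said of these compounds alone.

Working notes on the series, with three compounds measured so far in a functional assay on HepG2 cells (Homo sapiens) for cytotoxicity, read by MTT assay, with a stated time of 72 h; on this read-out higher numbers stand for weaker inhibition and lower numbers for stronger inhibition. Compound 3 `COc1cc2ncnc(Nc3ccc(F)c(Cl)c3)c2cc1NC(=O)N/N=C/c1ccc([N+](=O)[O-])cc1` gives 34100 nM and compound 2 `COc1cc2ncnc(Nc3ccc(F)c(Cl)c3)c2cc1NC(=O)N/N=C/c1ccc(C#N)cc1` gives 34100 nM, so the two stand level and share the highest number of the three. Compound 1 `O=C(N/N=C/c1cc(Br)c(O)c(Br)c1)Nc1cc2c(Nc3ccc(F)c(Cl)c3)ncnc2cc1O[C@H]1CCOC1` gives 2740 nM, a lower number than either, beyond the scatter.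

Next is compound 4 `COc1cc2ncnc(Nc3ccc(F)c(Cl)c3)c2cc1NC(=O)N/N=C/c1cc(Br)c(O)c(Br)c1`, reached from compound 3 by 3,5-dibromo-4-hydroxyphenyl in place of 4-nitrophenyl on a carbon with a double bond to nitrogen. For the measured compounds named here, the only measured step at this place is no change at the digits printed from compound 2 to compound 3 (within the scatter). That step shows no movement, but it does not involve the entering 3,5-dibromo-4-hydroxyphenyl, so it says little about this change. Going by the values given here, compound 1 is the only measured compound that carries this group, but its core is not that of compound 4, and no measured pair separates the two changes. The expectation of a lower number therefore rests on compound 1 at 2740 nM, and it is held loosely. A move beyond the scatter towards that value is expected, probably without reaching it. The expected step is a 5.7-fold lower number from compound 3 to compound 4 (0.75 log units; beyond the scatter). For compound 4 the estimate is 6000 nM, with an expected range from 1800 nM to 25000 nM.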

Compound 4, half-maximal inhibitory concentration: 36800 nM
The estimate for compound 4 lay 6.1-fold (0.79 log units) below the measured number; the whole stated range lies below it.
By their numbers in this assay, from the lowest: compound 1; then compounds 2, 3 and 4 (each within the scatter of the next).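

In this assay, at the carbon with a double bond to nitrogen, 3,5-dibromo-4-hydroxyphenyl in place of 4-nitrophenyl gives a 1.1-fold higher number from compound 3 to compound 4 (0.03 log units; within the scatter) and 3,5-dibromo-4-hydroxyphenyl in place of 4-cyanophenyl gives a 1.1-fold higher number from compound 2 to compound 4 (0.03 log units; within the scatter) so, with methyl on the oxygen, this position shows no separation among the three groups. The lower number of compound 1 is therefore not explained by 3,5-dibromo-4-hydroxyphenyl alone: the pair that separates the two changes, with methyl in place of oxolan-3-yl on an oxygen on an aromatic ring, gives a 13-fold higher number from compound 1 to compound 4 (1.13 log units; beyond the scatter) and places the large difference at that oxygen substituent when 3,5-dibromo-4-hydroxyphenyl is present. No measurement in hand offers a reason for either result.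

The compounds shown leave open whether oxolan-3-yl gives a comparable step with 4-nitrophenyl or 4-cyanophenyl, so the level seen among the three groups may hold only with methyl on that oxygen. They also leave open how a longer chain ending in an amine, or one ending in a carboxylic acid, on that oxygen would compare with methyl and oxolan-3-yl.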